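Swapping the Amine-Bearing Tail for an Ester Tail

The source may hold more compounds than are shown below. What is called first, only, known or untested is meant among the compounds shown, and "the series" means these compounds.

Measured so far in a functional assay on MCF7 cells (Homo sapiens) for antiproliferative activity, read by MTT assay, with a stated time of 48 h; on this read-out lower numbers stand for stronger inhibition and higher numbers for weaker inhibition:
- compound 1 `CCn1c(C(=O)NCCCN(C)C)ccc1C(CC)(CC)c1ccc(OCCC(O)(CC)CC)c(C)c1` gives 3350 nM
- compound 2 `CCn1c(C(=O)NCCN(C)C)ccc1C(CC)(CC)c1ccc(OCCC(O)(CC)CC)c(C)c1` gives 430 nM
- compound 3 `CCn1c(C(=O)NCCN)ccc1C(CC)(CC)c1ccc(OCCC(O)(CC)CC)c(C)c1` gives 670 nM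

Compound 3 stands second highest of these three numbers. Its nearest neighbour is compound 2, a 1.6-fold higher number from compound 2 to compound 3 (0.19 log units; within the scatter); its furthest is compound 1, a 5.0-fold lower number from compound 1 to compound 3 (0.70 log units; beyond the scatter). Compound 4 `CCOC(=O)CN(C)C(=O)c1ccc(C(CC)(CC)c2ccc(OCCC(O)(CC)CC)c(C)c2)n1CC` is the next step: ((ethoxycarbonyl)methyl)(methyl)amino in place of (2-aminoethyl)amino on a carbonyl carbon.

All three measured steps, a 7.8-fold lower number from compound 1 to compound 2 (0.89 log units; beyond the scatter), a 5.0-fold lower number from compound 1 to compound 3 (0.70 log units; beyond the scatter) and a 1.6-fold higher number from compound 2 to compound 3 (0.19 log units; within the scatter), only move or trim the amine on the chain; every measured compound keeps one. Among the compounds with values here, compound 4 keeps none, so no measured step covers this change, and the expectation is loose. A rise in the number is expected, a 4.5-fold higher number from compound 3 to compound 4 (0.65 log units; beyond the scatter). Compound 4 is estimated at 3000 nM, between 1000 nM and 12000 nM.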

Compound 4, half-maximal inhibitory concentration: 3210 nM
For compound 4 the middle estimate is 1.1-fold (0.03 log units) below the measured one; the measured number falls inside the stated range.
By their numbers in this assay, from the lowest: compounds 2 and 3 (each within the scatter of the next); then compounds 4 and 1 (each within the scatter of the next).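

With ((ethoxycarbonyl)methyl)(methyl)amino on the carbonyl carbon, the amine-free tail falls short of both shorter amine tails (a 4.8-fold higher number from compound 3 to compound 4 (0.68 log units; beyond the scatter)) and (a 7.5-fold higher number from compound 2 to compound 4 (0.87 log units; beyond the scatter)). Against the (3-(dimethylamino)propyl)amino tail it shows no real difference (a 1.0-fold lower number from compound 1 to compound 4 (0.02 log units; within the scatter)), so an amine on this tail does not by itself give the lower number. No measurement here explains these steps.

This change removes the amine and the amide hydrogen together, so their separate contributions remain unresolved. A carboxylic acid in place of the ethyl ester, or the same tail with the amide hydrogen kept, would help separate them.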